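Swapping an acid tail for an amine on the amide

The compounds below may be only part of what the source reports. "The series", "measured", "known", "first", "only" and "open" are said of these compounds alone.

Two compounds have been measured so far in an assay on HEK293 cells for agonist activity at Toll-like receptor 2 (Homo sapiens); a higher number here means that more compound is needed for the effect, a lower number that less compound is needed:

Compound 1, `CCCCCCCCCCCC(=O)OC[C@H](CSC[C@@H](N)C(=O)NC(CC)COC)OC(=O)CCCCCCCCCCC`, gives 71.8 nM.
Compound 2, `CCCCCCCCCCCC(=O)OC[C@H](CSC[C@@H](N)C(=O)NCCCCCC(=O)O)OC(=O)CCCCCCCCCCC`, gives 108 nM.

Compound 2 shows the higher of these two numbers, but the step of a 1.5-fold higher number from compound 1 to compound 2 (0.18 log units; within the scatter) lies within the scatter, so the two values cannot be told apart. Both share the same core, a lipid-bearing cysteine amide, and differ only in the group on the amide-type nitrogen.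

Compound 3, `CCCCCCCCCCCC(=O)OC[C@H](CSC[C@@H](N)C(=O)NCCCN)OC(=O)CCCCCCCCCCC`, keeps that core and alters the chain on the amide nitrogen once more: amino in place of 2-carboxyethyl on a saturated chain carbon, three bonds along the chain from an amide-type nitrogen. Going by the values given here, the only comparison that bears on this is the step from compound 1 to compound 2, which also changed the group on the amide nitrogen and stayed within the scatter. Nothing measured here speaks to a carboxylic acid against an amine, so an effect beyond the scatter cannot be foreseen in either direction.

Compound 3 is therefore expected to give about 90 nM in this assay, in the range 30 nM to 300 nM. The expected step is a 1.2-fold lower number from compound 2 to compound 3 (0.08 log units; within the scatter).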

Compound 3, half-maximal effective concentration: 1960 nM
The estimate for compound 3 lay 22-fold (1.34 log units) below the measured number, and the stated range ends below it.
By their numbers in this assay, from the lowest: compounds 1 and 2 (each within the scatter of the next); then compound 3.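

This result shows that the group on the amide nitrogen can matter a great deal in this assay, which the earlier pair could not show. Amino in place of 2-carboxyethyl on a saturated chain carbon, three bonds along the chain from an amide-type nitrogen, gives an 18-fold higher number from compound 2 to compound 3 (1.26 log units; beyond the scatter) and so goes well beyond the scatter that held the first step on this nitrogen. The 3-aminopropyl group also compares poorly with the 1-(methoxymethyl)propyl group of compound 1, with a 27-fold higher number from compound 1 to compound 3 (1.44 log units; beyond the scatter) on that replacement, so among these three compounds only compound 3 stands clearly apart, and no supporting measurement is at hand to explain the jump.

The step from compound 2 to compound 3 removes the acid and shortens the chain at once, so the compounds shown cannot separate the effect of the amine from the effect of chain length. An amine on a longer chain, such as 5-aminopentyl, would help to separate them, while a neutral end group on the same chain, such as 3-hydroxypropyl, would show whether the amine itself matters.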